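The source may report more compounds than this note shows. Statements on the series, on what has been measured and on what is new or still open speak of the compounds shown alone.

Compound 1 `CCCS(=O)(=O)Nc1cccc2c1CCC2c1ncc[nH]1` is the starting point of this step. In a functional assay on CHO cells for agonist activity at Alpha-1B adrenergic receptor (Homo sapiens), read by FLIPR and calcium flux (on this read-out higher numbers stand for an effect only at larger amounts of compound and lower numbers for an effect already at smaller amounts), compound 1 gives > 10000 nM, which is a limit of the measurement rather than a number. Compound 2 `CCS(=O)(=O)Nc1cccc(Cc2c[nH]cn2)c1` also reaches only a limit, giving > 10000 nM in this assay. Compound 3 `Cc1oncc1-c1cccc2c1CCC2c1ncc[nH]1` likewise gives > 10000 nM in this assay, again a limit. For the measured compounds named here, all three measured values therefore sit at the limit of > 10000 nM in this assay, at which 3 of the 3 values shown sit, and the one measured step that changes a single place, a step that the two limits leave unreadable from compound 1 to compound 3, cannot be read for size or direction.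

Compound 4 `c1cc(-c2cn[nH]c2)c2c(c1)C(c1ncc[nH]1)CC2` differs from compound 1 in one place: 1H-pyrazol-4-yl in place of (propylsulfonyl)amino on an aromatic carbon. Going by the values given here, no measured step with a readable size bears on this change, and the only related step, a step that the two limits leave unreadable from compound 1 to compound 3, shows that swapping the same (propylsulfonyl)amino group for another small five-membered aromatic ring did not bring the value inside the measurable window. The expectation for compound 4 is therefore that this assay will again most likely report only a limit, with an estimated step that the limit leaves unreadable from compound 1 to compound 4. The estimate for compound 4 is 15000 nM, expected to lie between 4000 nM and 60000 nM.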

Compound 4, half-maximal effective concentration: > 10000 nM
Compound 4: only a limit was reported; the forecaster's own chance of this, stated with the estimate: 85%; the middle value is on the limit's open side.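

In this assay compound 4 gives > 10000 nM as a limit, not a number, so the steps to compound 4 from compound 1 and from compound 3 cannot be read. The compounds shown leave open which change, if any, would bring a value inside the measurable range: the limit of > 10000 nM in this assay, at which 4 of the 4 values shown sit.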